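The source may hold more compounds than are shown below. What is called first, only, known or untested is meant among the compounds shown, and "the series" means these compounds.

In an assay on CHO cells for displacement of a labelled ligand from adenosine receptor A3 (Homo sapiens), read by scintillation counting, with a stated time of 60 min (on this read-out lower numbers stand for stronger inhibition and higher numbers for weaker inhibition), compound 1 `O=C(CCCc1ccccc1)Nc1nc2ccccc2c(=O)s1` sits at the limit > 1000 nM, which is not a number. Compound 2 `O=C(C/C=C/c1ccccc1)Nc1nc2ccccc2c(=O)s1` gives 158 nM. Compound 3 `O=C(CCc1ccccc1Br)Nc1nc2ccccc2c(=O)s1` likewise stands at the limit > 1000 nM, so for it only a limit is known. The step that the two limits leave unreadable from compound 1 to compound 3 therefore cannot be read, its size being hidden by the limit of > 1000 nM in this assay, at which 2 of the 3 values shown sit. Compound 4 `O=C(CCc1ccc(Cl)c(Cl)c1)Nc1nc2ccccc2c(=O)s1` differs from compound 3 by 3,4-dichlorophenyl in place of 2-bromophenyl on a saturated chain carbon, two bonds along the chain from a carbonyl carbon. The only measured step that bears on this change is the unreadable one, so no direction can be drawn from the shown numbers; a value no better than the limit appears most likely. Compound 4 is expected at 3000 nM, between 800 nM and 10000 nM. The expected step that the limit leaves unreadable from compound 3 to compound 4 is thus not beyond the scatter.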

Compound 4, inhibition constant: > 1000 nM
Compound 4 was reported as a limit; the forecaster's own chance of this, stated with the estimate: 70%; the middle value does not contradict the limit.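

Compound 4, like compound 1 and compound 3, is reported only as a limit and not as a number, so no step among these three compounds can be read: the limit of > 1000 nM in this assay, at which 3 of the 4 values shown sit. Whether 3,4-dichlorophenyl and 2-bromophenyl differ at all on this read-out stays open.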